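This account rests on a few compounds, and the source may have more. Where it says the series, first, only, none or still open, it means among the compounds named here.

Measured so far in an assay on CHO cells for displacement of a labelled ligand from adenosine receptor A3 (Homo sapiens), read by scintillation counting, with a stated time of 120 min, tested at 10 uM; on this read-out lower numbers stand for less inhibition and higher numbers for more inhibition at the one concentration tested (going by the name of the read-out):

Compound 1 `Nc1scc(CN2CCN(C3CCCCCC3)CC2)c1C(=O)c1ccc(Cl)cc1` gives 0%
Compound 2 `Nc1scc(CN2CCN(c3ccc(F)c(F)c3)CC2)c1C(=O)c1ccc(Cl)cc1` gives 1%
Compound 3 `Nc1scc(CN2CCN(c3c(F)cccc3F)CC2)c1C(=O)c1ccc(Cl)cc1` gives 4%

All three share the same core and differ only in the group on the amine nitrogen in the ring. Compound 3 carries the largest of the three numbers, but every step among them stays inside the usual scatter: a number 1 percentage points higher from compound 1 to compound 2 (within the scatter), a number 4 percentage points higher from compound 1 to compound 3 (within the scatter) and a number 3 percentage points higher from compound 2 to compound 3 (within the scatter). On this read-out the three compounds are not separated; their numbers are level within the scatter.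

Compound 4 `Nc1scc(CN2CCN(c3c(F)cc(F)cc3F)CC2)c1C(=O)c1ccc(Cl)cc1` is the next member. It differs from compound 3 by fluoro in place of hydrogen on an aromatic carbon. For the measured compounds named here, the steps that bear on this change are the ones that swap the group on the ring amine nitrogen, cycloheptyl against the two difluorophenyl patterns and those two against each other, and none of them moved the number beyond the scatter. Adding one more fluoro to the same phenyl ring is therefore expected to give no step beyond the scatter, no change at the digits printed from compound 3 to compound 4 (within the scatter). The expected value for compound 4 in this assay is 4%, with a range of -5% to 15%.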

Compound 4, a percentage reported as inhibition, at one concentration (the size of the read-out at that concentration, not a potency): 0%
For compound 4 the middle estimate is 4 percentage points above the measured one; the range from low to high includes it.
By their numbers in this assay, from the lowest: compounds 1, 4, 2 and 3 (each within the scatter of the next).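

Unlike the earlier steps, which swap the whole group on the ring amine nitrogen, this one changes a single aromatic carbon of the phenyl ring: in this assay, fluoro in place of hydrogen, meta to two fluoro groups and para to a large group, gives a number 4 percentage points lower from compound 3 to compound 4 (within the scatter) and so does not separate the 2,6-difluorophenyl and 2,4,6-trifluorophenyl compounds. The fully substituted pattern at these three ring carbons also stays level with the other two groups, with a number 1 percentage points lower from compound 2 to compound 4 (within the scatter) and with no change at the digits printed from compound 1 to compound 4 (within the scatter), so neither the cycloheptyl group nor any of the three fluorinated phenyl patterns stands apart on this read-out. No supporting evidence bears on this result.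

As far as these compounds go, with all four numbers this close to zero at the one concentration tested, the series gives no direction for the group on the ring amine nitrogen, and it remains open whether a different group there, such as a benzyl or a pyridyl group, would lift inhibition beyond the scatter. Also open, from the compounds shown here alone, is whether a methoxy or a trifluoromethyl group in place of the chloro on the shared core would alter this flat picture.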